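From 4-methylphenyl to 3,4-dimethoxyphenyl on a shared core

The source may hold more compounds than are shown below. What is called first, only, known or untested is meant among the compounds shown, and "the series" means these compounds.

Compound 1 `Cc1ccc(/C=C2\S/C(=N\c3csc(-c4ccc(Cl)cc4)c3)NC2=O)cc1`: 1500 nM
Compound 2 `CCCCCC/C=C1\S/C(=N\c2csc(-c3ccc(Cl)cc3)c2)NC1=O`: "not determined" (no result reported)

Within the data shown here, in a functional assay on SW-620 cells (Homo sapiens) for cytotoxicity, read by MTT assay, with a stated time of 72 h (a higher number here means a weaker inhibitor, a lower number a stronger inhibitor), compound 1 gives 1500 nM, the only number available. Compound 2 has the entry "not determined" (no result reported), so the two cannot be compared. Compound 3 `COc1ccc(/C=C2\S/C(=N\c3csc(-c4ccc(Cl)cc4)c3)NC2=O)cc1OC` keeps the core of compound 1 but carries 3,4-dimethoxyphenyl in place of 4-methylphenyl on a double-bonded chain carbon bound to a double-bonded ring carbon. Among the measured compounds shown here, no measured step shows what such a swap does, so the expected change is none beyond the scatter, an estimated 1.2-fold higher number from compound 1 to compound 3 (0.08 log units; within the scatter). For compound 3 the estimate is 1800 nM, expected to lie between 600 nM and 5500 nM.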

Compound 3, half-maximal inhibitory concentration: > 50000 nM
Compound 3: no number, only a limit (the forecaster's own chance of this, stated with the estimate: 10%); middle value at least 27-fold (1.44 log units) from the limit.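

In this assay, putting 3,4-dimethoxyphenyl in place of 4-methylphenyl on a double-bonded chain carbon bound to a double-bonded ring carbon gives an at least 33-fold higher number from compound 1 to compound 3 (1.52 log units; beyond the scatter), so activity here depends strongly on the group at this position. Among these compounds, this is the first measured evidence that the swap weakens the compound. For compound 3 the reading is a limit, not a number, so the full size of the loss stays unknown: the limit of > 50000 nM in this assay, at which 1 of the 3 values shown sits.

The compounds shown leave open whether the two methoxy groups are both needed for this loss. They also leave open how a plain phenyl or a single methoxy group would behave here.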